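Acetylation of a Second Hydroxy Group in Compound 1

This account rests on a few compounds, and the source may have more. Where it says the series, first, only, none or still open, it means among the compounds named here.

Compound 1, with the structure `CC(=O)Oc1cc(O)c2c(=O)c(-c3ccc(O)cc3)coc2c1`, is measured in a functional assay on HL-60 cells (Homo sapiens) for inhibition, read by MTT assay (a higher number here means a weaker inhibitor of growth, a lower number a stronger inhibitor of growth), and gives 4.95 uM. That is the highest of the three numbers at hand, so compound 1 is the weakest inhibitor of growth among them. Its nearest neighbour is compound 2, built as `CCCCCCCCCCOc1ccc(-c2coc3cc(OC(F)F)cc(OCCCCCCCCCC)c3c2=O)cc1`, which gives 1.63 uM; the gap to compound 1 lies beyond the scatter. Furthest away is compound 3, built as `CCCCCCCCOc1ccc(-c2coc3cc(OC(F)F)cc(OCCCCCCCC)c3c2=O)cc1`, which gives 0.47 uM, also beyond the scatter. Compounds 2 and 3 differ from compound 1 in several places at once, so no single step can be read from them.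

The new compound 4, with the structure `CC(=O)Oc1ccc(-c2coc3cc(OC(C)=O)cc(O)c3c2=O)cc1`, is obtained from compound 1 by one change: acetyl in place of hydrogen on an oxygen on an aromatic ring. Compound 1 already carries one acetoxy group on the shared core, and compound 4 carries a second one in place of a hydroxy.

Among the compounds with values here, no measured pair isolates this change, and the other two compounds are too different to guide. The step from compound 1 to compound 4 is therefore expected to be small, likely within the scatter, as a 1.2-fold lower number from compound 1 to compound 4 (0.09 log units; within the scatter). For compound 4 the expected value in this assay is 4 uM, with a range from 1.5 uM to 10 uM.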

Compound 4, concentration for growth inhibition (reported as GI): 5.86 uM
Compound 4: the middle estimate sits 1.5-fold (0.17 log units) below what was measured; the range from low to high includes it.
By their numbers in this assay, from the lowest: compound 3; then compound 2; then compounds 1 and 4 (each within the scatter of the next).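

Exchanging hydroxy for acetoxy on this oxygen on an aromatic ring gives a 1.2-fold higher number from compound 1 to compound 4 (0.07 log units; within the scatter) in this assay, so the two compounds cannot be told apart in this test of growth inhibition. Within the data shown here, this is the first step that changes a single place, and it shows that an acetyl, with its 3 heavy atoms, can replace the hydrogen here without a difference that rises above the scatter, even though compound 4 then carries acetoxy in two places. No measurement at hand bears on the reason for this result.

As far as these compounds go, whether this oxygen would tolerate other groups just as well remains open, for example a methyl ether, a longer acyl chain such as hexanoyl, or a chain ending in an amine. From the compounds shown here alone, compounds 2 and 3 differ from compound 1 in several places at once, so the steps to them cannot be read, and it also remains open which of their groups account for their values, or whether the same exchange would read the same way on a differently substituted core.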